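The compounds below may be only part of what the source reports. "The series", "measured", "known", "first", "only" and "open" are said of these compounds alone.

Measured in an ADME assay on KB cells (Homo sapiens) for cytotoxicity; a higher number here means that more compound is needed for the effect, a lower number that less compound is needed:
compound 1 `CCOC(=O)N1[C@@H]2C=C[C@@](OC)(C(=O)c3c2cc(OC)c(OC)c3OCc2ccccc2F)N1C(=O)OCC`, 99.7 ug/mL
compound 2 `CCCCOc1c(OC)c(OC)cc2c1C(=O)[C@]1(OC)C=C[C@H]2N(C(=O)OCC)N1C(=O)OCC`, 76 ug/mL
compound 3 `CCCCOc1c(OC)c(OC)cc2c1C(=O)[C@]1(OC)C=C[C@H]2N(C(=O)OCC(C)C)N1C(=O)OCC(C)C`, 22.1 ug/mL

Compound 2 and compound 1 differ only by 2-fluorophenyl in place of propyl on a saturated chain carbon bound to an oxygen on an aromatic ring; the step is a 1.3-fold higher number from compound 2 to compound 1 (0.12 log units; within the scatter). Compound 3 gives the lowest number of the three, beyond the scatter from both compound 2 and compound 1; the difference between the core of compound 3 and that of compound 2 is not broken down here.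

Compound 4 `COc1cc2c(c(OCc3ccccc3F)c1OC)C(=O)[C@]1(OC)C=C[C@H]2N(C(=O)OCC(C)C)N1C(=O)OCC(C)C` is not yet measured in this assay. It differs from compound 3 by 2-fluorophenyl in place of propyl on a saturated chain carbon bound to an oxygen on an aromatic ring, the same change in the same place as that from compound 2 to compound 1. Because the same change earlier gave a 1.3-fold higher number from compound 2 to compound 1 (0.12 log units; within the scatter), the expected step is a 1.2-fold higher number from compound 3 to compound 4 (0.09 log units; within the scatter), small and within the scatter. Compound 4 is thus expected to give about 27 ug/mL, between 12 ug/mL and 60 ug/mL.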

Compound 4, concentration for half-maximal effect: 109 ug/mL
For compound 4 the middle estimate is 4.0-fold (0.61 log units) below the measured one; measured number above the stated range.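

In this assay, replacing butoxy by (2-fluorobenzyl)oxy gives a 4.9-fold higher number from compound 3 to compound 4 (0.69 log units; beyond the scatter), and the change does not carry over with the same size from one core to the other: the same change on two cores in this assay, a 1.3-fold higher number (0.12 log units; within the scatter) from compound 2 to compound 1 and a 4.9-fold higher number (0.69 log units; beyond the scatter) from compound 3 to compound 4, 3.8-fold (0.58 log units) apart, beyond the scatter of two such steps. Within these four compounds, the size of the step on one core is therefore a poor guide to its size on the other. Two pairs do not show why the cores differ, or which of the two steps would be more typical on further cores.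

As far as these compounds go, it remains open whether the same dependence on the core appears with other groups on that oxygen, such as unsubstituted benzyl or a longer chain. A chain ending in an amine or a carboxylic acid is equally untested here.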